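The source may hold more compounds than are shown below. What is called first, only, known or untested is meant among the compounds shown, and "the series" means these compounds.

Compound 1 `CN1CCC[C@@H]1Cn1nc(Cc2cccc(Cl)c2)c2ccccc2c1=O` is examined in an assay for binding affinity to Alpha-1B adrenergic receptor (Homo sapiens) (on this read-out lower numbers stand for stronger inhibition and higher numbers for weaker inhibition), where compound 1 gives 631 nM. Among the compounds with values here, of the two compounds measured so far, compound 1 carries the larger number; the other, compound 2 `CN1CCCC1CCn1nc(Cc2ccc(Cl)cc2)c2ccccc2c1=O`, gives 316 nM in this assay, and the two values sit within the scatter of one another, so they cannot be told apart in binding strength. Compound 3 `COc1cccc(Cc2nn(C[C@H]3CCCN3C)c(=O)c3ccccc23)c1` has not yet been measured. It differs from compound 1 in a single place: methoxy in place of chloro on an aromatic carbon. Within the data shown here, no measured pair shows this exchange, so the size of the step in this assay is open. The exchange is expected to move the number only modestly, if at all, with a step from compound 1 to compound 3 of about a 1.3-fold higher number from compound 1 to compound 3 (0.10 log units; within the scatter) anticipated. On that basis compound 3 is estimated at 800 nM in this assay, within a range from 300 nM to 2000 nM.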

Compound 3, inhibition constant: > 1990 nM
Compound 3: only a limit was reported (the forecaster's own chance of this, stated with the estimate: 5%); at least 2.4-fold (0.39 log units) between middle value and limit.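

Within the data shown here, compound 1 and compound 2 differed in more than one place, so they gave no single-change step; this pair gives the first. On the six-membered aromatic ring of the benzyl group, going from 3-chlorobenzyl to 3-methoxybenzyl yields an at least 3.1-fold higher number from compound 1 to compound 3 (0.49 log units; beyond the scatter) in this assay, which shows that binding in this assay is sensitive to the group at this position. The result for compound 3 is a limit, so the step has a lower bound but no known full size: the limit of > 1990 nM in this assay, at which 1 of the 3 values shown sits.

This single pair cannot show whether the same exchange would have a similar effect at other positions on the ring or with the longer chain of compound 2. It also leaves open how a fluoro, methyl or hydroxy group would read at this position, and so whether chloro is unusual here or methoxy alone is poorly accepted.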